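Urea-to-amide swap on the shared core, growth at low dose

A few compounds are considered here, and "the series" means these few. Any claim that something is new, unique, unknown or untested is made for them only; others in the source may bear on it.

Measured so far in a functional assay on SN12C cells (Homo sapiens) for inhibition, read by sulforhodamine B assay, with a stated time of 48 h, tested at 0.01 uM; a higher number here means a weaker effect of the compound at the concentration tested, a lower number a stronger effect:
compound 1, `O=C(Nc1cccc(-n2cc(-c3ccncc3)c(-c3cc(O)cc(Cl)c3)n2)c1)Nc1ccc(Cl)c(Cl)c1`, 100%
compound 2, `COc1cc(Cl)cc(-c2nn(-c3cccc(NC(=O)Nc4cc(C(F)(F)F)cc(C(F)(F)F)c4)c3)cc2-c2ccncc2)c1`, 96%
compound 3, `COc1cc(Cl)cc(-c2nn(-c3cccc(NC(=O)Nc4ccc(Cl)c(Cl)c4)c3)cc2-c2ccncc2)c1`, 97%

Compound 3 sits among the measured values: its nearest neighbour is compound 2, and its furthest is compound 1, and each of these gaps lies within the scatter of repeated measurements, so the three numbers read as one level. Going by the values given here, the only step between compounds that differ in one place is a number 3 percentage points lower from compound 1 to compound 3 (within the scatter), and it touches a different part of the molecule, the oxygen on an aromatic ring, not the carbonyl.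

Compound 4, `COc1cc(Cl)cc(-c2nn(-c3cccc(NC(=O)c4cccc(C(F)(F)F)c4)c3)cc2-c2ccncc2)c1`, is not yet measured. It differs from compound 3 by 3-(trifluoromethyl)phenyl in place of (3,4-dichlorophenyl)amino on a carbonyl carbon. Among the compounds with values here, no measured step bears on this change directly; compound 2 and compound 3 share the carbonyl carbon with an amino group on it and differ only in the aryl part, and their two values lie within the scatter. What the series shows so far is a flat level at this concentration, with no change yet moving the number beyond the scatter. On that basis, compound 4 is expected to stay on the same level, with no change at the digits printed from compound 3 to compound 4 (within the scatter) expected as a step no larger than the scatter. The estimate for compound 4 in this assay is 97%, expected between 87% and 100%.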

Compound 4, a percentage reported as activity, at one concentration (the size of the read-out at that concentration, not a potency): 99%
For compound 4 the middle estimate is 2 percentage points below the measured one; the range from low to high includes it.
By their numbers in this assay, from the lowest: compounds 2, 3, 4 and 1 (each within the scatter of the next).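

Going by these compounds alone, compound 4 is the first change at the carbonyl carbon itself: with 3-(trifluoromethyl)phenyl in place of (3,4-dichlorophenyl)amino, the urea of compound 3 becomes an amide, and in this assay this reads as a number 2 percentage points higher from compound 3 to compound 4 (within the scatter). The earlier compounds shown here varied only the aryl part of the urea and the oxygen on an aromatic ring, whereas this step also removes the amino group's 1 hydrogen-bond donor, and the read-out at this single low concentration stays on the same level, so the urea is not required to hold that level. No supporting measurement bears on why this level persists.

The step changes the link to the carbonyl and the substitution on the aryl ring together, so the compounds shown do not separate the two contributions, and a flat read-out at one concentration gives no measure of potency. Also open, going by these compounds, is whether a different group on that aryl ring, such as a carboxylic acid or a dimethylamino group, or a longer chain between the carbonyl and the ring, would move the number beyond the scatter.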